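This account rests on a few compounds, and the source may have more. Where it says the series, first, only, none or still open, it means among the compounds named here.

Compound 1 `CCN(CC)C(=O)C1=C(C)NC(=O)NC1c1ccco1` is the reference point. In an assay on membranes from HeLa cells for displacement of a labelled ligand from adenosine receptor A3 (Homo sapiens), read by scintillation counting, with a stated time of 180 min, tested at 1 uM (on this read-out higher numbers stand for more inhibition at the one concentration tested (going by the name of the read-out) and lower numbers for less inhibition), compound 1 gives 19%, the lowest of the three numbers measured. Compound 2 `CCN(CC)C(=O)C1=C(C)NC(=O)NC1c1ccoc1` gives 37% in this assay, a step of a number 18 percentage points higher from compound 1 to compound 2 (beyond the scatter). Compound 3 `CCN(CC)C(=O)C1=C(C)NC(=O)NC1c1ccsc1` gives 35% in this assay, a step of a number 16 percentage points higher from compound 1 to compound 3 (beyond the scatter); the step of a number 2 percentage points lower from compound 2 to compound 3 (within the scatter) is within the scatter. Compound 4 `CC1=C(C(=O)OCC2CC2)C(c2ccco2)NC(=O)N1` differs from compound 1 in a single place: cyclopropylmethoxy in place of diethylamino on a carbonyl carbon. Among the measured compounds shown here, none of the measured steps bears on this change: all three exchange furan-2-yl, furan-3-yl or thiophen-3-yl on the saturated ring carbon, while the group on the carbonyl carbon stays diethylamino throughout. So no step of known size guides the expectation here, and compound 4 is expected to show a step of a number 6 percentage points higher from compound 1 to compound 4 (within the scatter), which is taken as no clear change beyond the scatter but with a wide margin. Compound 4 is therefore estimated at 25%, between 5% and 50%.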

Compound 4, a percentage reported as inhibition, at one concentration (the size of the read-out at that concentration, not a potency): 1%
Estimate against measurement, compound 4: 24 percentage points above; the whole stated range lies above it.
By their numbers in this assay, from the lowest: compound 4; then compound 1; then compounds 3 and 2 (each within the scatter of the next).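

With furan-2-yl held in place, the group on the carbonyl carbon proves not to be indifferent in this assay: cyclopropylmethoxy in place of diethylamino gives a number 18 percentage points lower from compound 1 to compound 4 (beyond the scatter), and compound 4 shows almost no inhibition at 1% at the one concentration tested. Among the compounds shown here, the earlier compounds all carried diethylamino and varied only the group on the saturated ring carbon, so this is the first sign that the carbonyl substituent also moves the number. The change swaps nitrogen for oxygen and brings in a three-membered ring at the same time, and nothing shown explains the drop or divides it between these two features.

From the compounds shown here alone, it remains open whether an ethoxy group or a pyrrolidin-1-yl group on the carbonyl carbon would keep or lose the inhibition. Going by these compounds, it is also open whether cyclopropylmethoxy would have the same effect alongside furan-3-yl or thiophen-3-yl.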